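The source may report more compounds than this note shows. Statements on the series, on what has been measured and on what is new or still open speak of the compounds shown alone.

Measured in a functional assay on cells for antagonist activity at Glucagon receptor (Homo sapiens), read by cAMP accumulation, in the presence of a further agent that is not named here; a higher number here means a weaker inhibitor, a lower number a stronger inhibitor:
Compound 1 `CCCC(Oc1ccc(-n2cc3ccccc3n2)cc1)c1ccc(C(=O)NCCC(=O)O)cc1`: 2000 nM
Compound 2 `O=C(O)CCNC(=O)c1ccc(C(Oc2ccc(-n3cc(C(F)(F)F)cn3)cc2)C2CCC2)cc1`: 3000 nM

In this assay compound 1 and compound 2 sit within the usual scatter of each other, so neither can be set apart from the other on the numbers shown. Compound 3 `CCCC(Oc1ccc(-n2cc(C(F)(F)F)c(C)n2)cc1)c1ccc(C(=O)NCCC(=O)O)cc1` differs from compound 1 by 3-methyl-4-(trifluoromethyl)-1H-pyrazol-1-yl in place of 2H-indazol-2-yl on an aromatic carbon. For the measured compounds named here, no step between measured compounds tells how this change acts, and compound 2 already carries a trifluoromethyl-bearing pyrazole with a number close to that of compound 1, so the expected step from compound 1 to compound 3 is a 1.3-fold higher number from compound 1 to compound 3 (0.10 log units; within the scatter), none beyond the scatter. Compound 3 is estimated at 2500 nM, within 900 nM to 7000 nM.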

Compound 3, antagonist equilibrium constant: 8300 nM
Compound 3: middle estimate off by 3.3-fold (0.52 log units), on the low side, outside the stated range (above it).
By their numbers in this assay, from the lowest: compounds 1 and 2 (each within the scatter of the next); then compound 3.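

In this assay, the group on this aromatic carbon, para to a large group, proves able to shift the number: 3-methyl-4-(trifluoromethyl)-1H-pyrazol-1-yl in place of 2H-indazol-2-yl gives a 4.2-fold higher number from compound 1 to compound 3 (0.62 log units; beyond the scatter) on the shared core, a step beyond the scatter. For the compounds shown here, this is the first change in one place that can be read, and it runs toward a weaker inhibitor.

Still open, on these data alone, is whether the step follows the loss of the six-membered aromatic ring or the presence of the methyl, which a pyrazole on the core of compound 1 bearing only trifluoromethyl, or a nitrile in its place, could help separate. Nothing shown accounts for the step.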